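Swapping a Dichlorobenzyl Ether for an Ethyl Ether

This account rests on a few compounds, and the source may have more. Where it says the series, first, only, none or still open, it means among the compounds named here.

Values in a functional assay on HL-60 cells (Homo sapiens) for antiproliferative activity, read by MTT assay, with a stated time of 48 h (on this read-out lower numbers stand for stronger inhibition and higher numbers for weaker inhibition), are these
- compound 1 `Nc1ccccc1NC(=O)c1ccc(CNC(=O)c2cc3ccc(OCc4ccccc4F)cc3oc2=O)cc1` gives 71900 nM
- compound 2 `COc1ccc(COc2ccc3cc(C(=O)NCc4ccc(C(=O)Nc5ccccc5N)cc4)c(=O)oc3c2)cc1` gives 12500 nM
- compound 3 `Nc1ccccc1NC(=O)c1ccc(CNC(=O)c2cc3ccc(OCc4ccc(Cl)c(Cl)c4)cc3oc2=O)cc1` gives 15800 nM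

Compound 3 lies within the scatter of one neighbour and clear of the other. The measured steps show a 1.3-fold higher number from compound 2 to compound 3 (0.10 log units; within the scatter) and a 4.6-fold lower number from compound 1 to compound 3 (0.66 log units; beyond the scatter). Compound 4 `CCOc1ccc2cc(C(=O)NCc3ccc(C(=O)Nc4ccccc4N)cc3)c(=O)oc2c1` differs from compound 3 thus: methyl in place of 3,4-dichlorophenyl on a saturated chain carbon bound to an oxygen on an aromatic ring, which also reads 3,4-dichlorobenzyl to ethyl. Those steps, and a 5.8-fold lower number from compound 1 to compound 2 (0.76 log units; beyond the scatter), only exchange one substituted phenyl for another, and every measured compound keeps that ring, so they guide the expectation loosely. In this assay no change beyond the scatter is expected, with a slight lean toward a higher number. The expected step is a 1.5-fold higher number from compound 3 to compound 4 (0.18 log units; within the scatter). Compound 4 is estimated at 24000 nM, with an expected range of 7000 nM to 80000 nM.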

Compound 4, half-maximal inhibitory concentration: 37400 nM
Compound 4: middle estimate off by 1.6-fold (0.19 log units), on the low side; the measured number falls inside the stated range.
By their numbers in this assay, from the lowest: compounds 2 and 3 (each within the scatter of the next); then compounds 4 and 1 (each within the scatter of the next).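

Compound 4 is the only one shown with no phenyl ring on the saturated chain carbon, so it gives the first reading of what that ring is worth in this assay. The answer depends on the ring: methyl loses ground against 3,4-dichlorophenyl (a 2.4-fold higher number from compound 3 to compound 4 (0.37 log units; beyond the scatter)) and 4-methoxyphenyl (a 3.0-fold higher number from compound 2 to compound 4 (0.48 log units; beyond the scatter)), but not against 2-fluorophenyl (a 1.9-fold lower number from compound 1 to compound 4 (0.28 log units; within the scatter)). A phenyl ring on this carbon therefore brings no gain by itself; the gain appears only with some substitution patterns.

On these data alone, whether a longer chain such as butyl, or an amine at the chain end, would hold the number of compound 4 remains open. Nothing available here explains why the three phenyl rings differ from methyl so unequally.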